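Ester to free acid on the inactive malonamide series

A few compounds are considered here, and "the series" means these few. Any claim that something is new, unique, unknown or untested is made for them only; others in the source may bear on it.

The series shares a core built from a lactam bearing a propyl-substituted malonamide arm, as in compound 1 `CCCN(C(=O)CC(=O)O)C1=C(C)CC(c2ccc(C(=N)N)cc2)N([C@@H](C)c2ccc(OC)cc2)C1=O` and compound 2 `CCCN(C(=O)C(CC(=O)OC)C(=O)O)C1=C(C)CC(c2ccccc2)N(Cc2ccc(N)cc2)C1=O`. In an assay on K562 cells for inhibition of integrin alpha-5/beta-1 (Homo sapiens) (a lower number here means a stronger inhibitor, a higher number a weaker inhibitor), compound 1 returns only a limit, > 1000000 nM. In this assay compound 2 likewise returns only a limit, > 1000000 nM. Compound 2 therefore stands at the ceiling of what is shown, with no number to rank it against: the limit of > 1000000 nM in this assay, at which 2 of the 2 values shown sit.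

Compound 3 `CCCN(C(=O)C(CC(=O)O)C(=O)O)C1=C(C)CC(c2ccccc2)N(Cc2ccc(N)cc2)C1=O` is the next variant. It differs from compound 2 in one place, (hydrogen in place of methyl on an oxygen next to a carbonyl group), that is, hydrogen in place of methyl on an oxygen next to a carbonyl group, so that the methoxycarbonyl becomes a carboxy group. No step between two measured compounds is available to calibrate this change, and both shown values sit at the limit, so the shown numbers give no direction.

The step from compound 2 to compound 3 is expected to be an at least 3.3-fold lower number from compound 2 to compound 3 (0.52 log units; beyond the scatter), most likely nothing resolvable beyond the scatter, with a modest chance of a gain. Compound 3 is estimated at 300000 nM in this assay, between 5000 nM and 1000000 nM.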

Compound 3, half-maximal inhibitory concentration: > 1000000 nM
Compound 3 was reported as a limit; the forecaster's own chance of this, stated with the estimate: 65%; at least 3.3-fold (0.52 log units) between middle value and limit.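

In this assay compound 3 gives > 1000000 nM as a limit and not a number. Within the data shown here, no step from compound 2 to compound 3 can be read, and the values shown share one ceiling: the limit of > 1000000 nM in this assay, at which 3 of the 3 values shown sit. Still open, going by these compounds, is whether methoxycarbonyl to carboxy changes inhibition at all, and whether any compound reaches a measurable value.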